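This account rests on a few compounds, and the source may have more. Where it says the series, first, only, none or still open, it means among the compounds named here.

Working notes on the series. In a functional assay on U-373MG ATCC cells for inhibition, with U373 MG (Homo sapiens) as the target, read by MTT assay, with a stated time of 7 days (a higher number here means a weaker inhibitor of growth, a lower number a stronger inhibitor of growth), compound 1 (`NC(=O)c1nc[nH]c1N/N=N/Cc1ccccc1`) gives > 50000 nM, which is a limit and not a number. In this assay, compound 2 (`NC(=O)c1nc[nH]c1N/N=N/Cc1ccco1`) gives > 50000 nM, again a limit and not a number. Compound 2 therefore has no exact position in the series, and the evidence amounts to the limit of > 50000 nM in this assay, at which 2 of the 2 values shown sit.

Compound 3 (`NC(=O)c1nc[nH]c1N/N=N/Cc1cccs1`) has thiophen-2-yl in place of furan-2-yl on a saturated chain carbon bound to a double-bonded nitrogen. For the measured compounds named here, the only measured step that bears on this change is a step that the two limits leave unreadable from compound 1 to compound 2. It also concerns the group on the saturated chain carbon, but it gives no size to carry forward. Going by the values given here, with only that unreadable step and the limit of compound 2 at > 50000 nM to go on, no step beyond the scatter is expected in this assay, in either direction. The estimated step is a step that the limit leaves unreadable from compound 2 to compound 3. Compound 3 is expected at 60000 nM, with an estimated range of 25000 nM to 100000 nM, and a report of only a limit is the likeliest outcome.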

Compound 3, concentration for 50% growth inhibition: > 50000 nM
Compound 3: only a limit was reported; the forecaster's own chance of this, stated with the estimate: 75%; the middle value does not contradict the limit.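

In this assay, for the compounds shown here, compound 3 gives > 50000 nM, a limit and not a number, so no step among compound 1, compound 2 and compound 3 can be read. The evidence stands as: the limit of > 50000 nM in this assay, at which 3 of the 3 values shown sit.

The compounds shown leave open whether phenyl, furan-2-yl and thiophen-2-yl differ at all in growth inhibition.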